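The source may hold more compounds than are shown below. What is called first, only, known or untested is meant among the compounds shown, and "the series" means these compounds.

Of the compounds shown here, two built on one shared core have been measured in a toxicity assay on microsomes from liver (Homo sapiens) for metabolic stability, read by LC-MS, using NADPH, tested at 1 uM; on this read-out higher numbers stand for fast clearance and lower numbers for slow clearance. Within the data shown here, compound 1 (`CCc1ncc(-c2nc(C(F)(F)F)sc2N2CCN(C(=O)Cn3nc(C)nc3C)[C@H](C)C2)cn1`) gives 43 mL.min-1.g-1, and compound 2 (`CCCc1ncc(-c2nc(C(F)(F)F)sc2N2CCN(C(=O)Cn3nc(C)nc3C)[C@H](C)C2)cn1`) gives 80 mL.min-1.g-1, so compound 2 stands within the usual scatter of the only other number available. Compound 3 (`COc1ccc(-c2nc(C(F)(F)F)sc2N2CCN(C(=O)Cn3nc(C)nc3C)[C@H](C)C2)cn1`) keeps that core but carries a different aromatic group: 6-methoxypyridin-3-yl in place of 2-propylpyrimidin-5-yl on an aromatic carbon. Here 6-methoxypyridin-3-yl sits in place of 2-propylpyrimidin-5-yl, on an aromatic carbon of a five-membered aromatic ring with 1 nitrogen and 1 sulfur. Among the measured compounds shown here, only one measured step exists to lean on, a 1.9-fold higher number from compound 1 to compound 2 (0.27 log units; within the scatter), and it stays within the scatter. For the measured compounds named here, that step changed the length of a chain and left the ring in place, so it is a weak guide, and no measured pair shows what exchanging the whole group does. No clear direction can therefore be drawn, and no shift beyond the scatter is expected. The expected change is a 1.5-fold lower number from compound 2 to compound 3 (0.16 log units; within the scatter). Compound 3 is estimated at 55 mL.min-1.g-1, with an expected range from 20 mL.min-1.g-1 to 130 mL.min-1.g-1.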

Compound 3, intrinsic clearance in microsomes: < 10 mL.min-1.g-1
Compound 3: a limit, no number; the forecaster's own chance of this, stated with the estimate: 5%; middle value at least 5.5-fold (0.74 log units) away from the limit.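

In this assay, placing 6-methoxypyridin-3-yl on this aromatic carbon in place of 2-propylpyrimidin-5-yl gives an at least 8.0-fold lower number from compound 2 to compound 3 (0.90 log units; beyond the scatter), and placing it there in place of 2-ethylpyrimidin-5-yl gives an at least 4.3-fold lower number from compound 1 to compound 3 (0.63 log units; beyond the scatter). Among these compounds, both steps lie beyond the scatter, whereas the only earlier step, a 1.9-fold higher number from compound 1 to compound 2 (0.27 log units; within the scatter), stayed within it, so this position shows a clear response to exchanging the whole aromatic group that the change in chain length did not reveal. The reading for compound 3 is a limit of the assay and not a number: the limit of < 10 mL.min-1.g-1 in this assay, at which 1 of the 3 values shown sits.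

The exchange alters two things at once, replacing a ring with 2 hetero atoms by a ring with 1 hetero atom and replacing a saturated chain by a methoxy group, and the compounds shown cannot tell which of these goes with the step. A 2-methoxypyrimidin-5-yl group or a 6-propylpyridin-3-yl group at the same place would pull these two changes apart, since each would carry only one of them.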